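The source may report more compounds than this note shows. Statements on the series, on what has been measured and on what is new or still open speak of the compounds shown alone.

Compounds measured so far:
- compound 1, `CN(c1ccc(Oc2ncnc3ccsc23)cc1)c1nccc(N2CCc3ccccc3C2)n1`: 30.2% in a functional assay on MDA-MB-231 cells (Homo sapiens) for inhibition, read by MTT assay, with a stated time of 72 h, tested at 20 uM; a lower number here means less inhibition, a higher number more inhibition at the concentration tested (going by the name of the read-out)
- compound 2, `CN(c1ccc(Oc2ncnc3ccsc23)cc1)c1nccc(N2CCc3ccccc32)n1`: 38.2% in this assay

Compound 1 has the lower of the two numbers; its nearest neighbour is compound 2, and the step of a number 8 percentage points higher from compound 1 to compound 2 (within the scatter) lies within the scatter. Compound 3, `c1ccc2c(c1)CCN(c1ccnc(Nc3ccc(Oc4ncnc5ccsc45)cc3)n1)C2`, differs from compound 1 in one place: hydrogen in place of methyl on a nitrogen on an aromatic ring. For the measured compounds named here, no measured step removes this methyl, and the only step at hand, a number 8 percentage points higher from compound 1 to compound 2 (within the scatter), concerns another group and stays within the scatter. Compound 3 is therefore expected to show no step beyond the scatter, a number 1.8 percentage points higher from compound 1 to compound 3 (within the scatter). Compound 3 is estimated at 32%, ranging from 15% to 50%.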

Compound 3, a percentage reported as inhibition, at one concentration (the size of the read-out at that concentration, not a potency): 15.4%
Compound 3: the middle estimate sits 16.6 percentage points above what was measured; the range from low to high includes it.
By their numbers in this assay, from the lowest: compound 3; then compounds 1 and 2 (each within the scatter of the next).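

Hydrogen in place of methyl on the nitrogen on an aromatic ring gives a number 14.8 percentage points lower from compound 1 to compound 3 (beyond the scatter) in this assay. This is the first step among these compounds to lie beyond the scatter, so this nitrogen is a place where the read-out responds to a single methyl. Nothing available explains the drop. Going by these compounds, whether an ethyl group or a longer chain on this nitrogen would keep or raise the number remains open. Also open, on these data alone, is whether removing the methyl has the same effect with the 2,3-dihydro-1H-indol-1-yl group of compound 2.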